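The source may report more compounds than this note shows. Statements on the series, on what has been measured and on what is new or still open speak of the compounds shown alone.

In an ADME assay on MT4 cells (Homo sapiens) for activation, read by MTT assay (a lower number here means that less compound is tolerated, a higher number that more compound is tolerated), compound 1 `CCCCSc1nc(C(C)c2c(F)cccc2Cl)c(CC)c(=O)[nH]1` gives > 3000 nM, which is a limit of the assay and not a number. Compound 2 `CCc1c(C(C)c2c(F)cccc2F)nc(SC(C)CC)[nH]c1=O` gives > 3000 nM, again only a limit. Among the measured compounds shown here, the series so far stands at the limit of > 3000 nM in this assay, at which 2 of the 2 values shown sit. Compound 3 `CCCCSc1nc(C(C)c2c(F)cccc2F)c(CC)c(=O)[nH]1` has butyl in place of sec-butyl on a sulfur. For the measured compounds named here, no measured step in this assay covers this change, and no shift beyond the usual scatter is expected in either direction. The expected change is a step that the limit leaves unreadable from compound 2 to compound 3. For compound 3 the estimate is 5000 nM, in an expected range of 3000 nM to 30000 nM, and a report as a limit alone is likely.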

Compound 3, half-maximal cytotoxic concentration: > 3000 nM
Compound 3 ended at the assay's limit; the forecaster's own chance of this, stated with the estimate: 85%; the middle value lies beyond the limit too.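

In this assay, the steps from compound 1 and compound 2 to compound 3 cannot be read, as all three compounds give only a limit of the assay: the limit of > 3000 nM in this assay, at which 3 of the 3 values shown sit. Where each compound's true value lies, and whether butyl in place of sec-butyl or fluoro in place of chloro changes it, stays open.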